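Exchanging the Ring on the Amide Nitrogen

This account rests on a few compounds, and the source may have more. Where it says the series, first, only, none or still open, it means among the compounds named here.

Two compounds of one series share a large common core and differ only in the aromatic ring attached to one amide nitrogen. Compound 1 `CN(C)C(=O)c1cc2cnc(Nc3ccc(NC(=O)C4(C(=O)Nc5ccccc5F)CC4)cc3)nc2n1C1CCCC1` carries a 2-fluorophenyl there, and in a functional assay on NCI-H1299 cells (Homo sapiens) for inhibition, read by CCK-8 assay, with a stated time of 72 h, tested at 10 uM (on this read-out higher numbers stand for more inhibition of growth at the one concentration tested and lower numbers for less inhibition of growth), compound 1 gives 89.6%. Compound 2 `CN(C)C(=O)c1cc2cnc(Nc3ccc(NC(=O)C4(C(=O)Nc5cccc(Cl)c5)CC4)cc3)nc2n1C1CCCC1` carries a 3-chlorophenyl instead, and in this assay compound 2 gives 84.1%. That exchange produced a number 5.5 percentage points lower from compound 1 to compound 2 (within the scatter), so the two readings cannot be told apart. For the measured compounds named here, compound 2 thus holds the lower of the two numbers, but its only neighbour, compound 1, sits within the scatter of it.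

Compound 3 `Cc1ccc(NC(=O)C2(C(=O)Nc3ccc(Nc4ncc5cc(C(=O)N(C)C)n(C6CCCC6)c5n4)cc3)CC2)cc1` has not yet been measured. It differs from compound 2 in one place: 4-methylphenyl in place of 3-chlorophenyl on an amide-type nitrogen. Going by the values given here, the only step seen so far, a number 5.5 percentage points lower from compound 1 to compound 2 (within the scatter), also swapped one such ring for another, and it left the read-out unmoved beyond the scatter; no other comparison is available. On that basis the step from compound 2 to compound 3 is expected to be small too, a number 0.9 percentage points higher from compound 2 to compound 3 (within the scatter), with no direction that exceeds the scatter. Compound 3 is therefore estimated at 85% in this assay, within a range from 72% to 95%.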

Compound 3, percent growth inhibition at one concentration: 84.5%
The estimate for compound 3 lay 0.5 percentage points above the measured number, within the range that was stated.
By their numbers in this assay, from the lowest: compounds 2, 3 and 1 (each within the scatter of the next).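

With compound 3, this position on the amide-type nitrogen has carried three different rings, and in this assay the three readings cannot be told apart: the listed steps are a number 0.4 percentage points higher from compound 2 to compound 3 (within the scatter) and a number 5.1 percentage points lower from compound 1 to compound 3 (within the scatter) and both lie within the scatter. For the compounds shown here, the earlier pair offered only one exchange, whereas this result adds a ring with a carbon-only substituent, the methyl of 4-methylphenyl, to the rings carrying fluorine and chlorine. Across 2-fluorophenyl, 3-chlorophenyl and 4-methylphenyl, neither the kind of substituent nor its numbered place on the ring separates these three compounds in this read-out, and nothing available explains that agreement.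

Going by these compounds, all three groups are phenyl rings with a single small substituent, so it remains open whether a ring bearing a carboxylic acid or an amine, or a longer chain in place of the ring, would give a reading outside the scatter. Each reading also comes from one concentration, which leaves open whether these three compounds would still match at lower concentrations.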